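Truncating the alkynyl substituent of compound 1 to a bare ethynyl

This account rests on a few compounds, and the source may have more. Where it says the series, first, only, none or still open, it means among the compounds named here.

For the measured compounds named here, compound 1 `CONc1nc(C#CCC(C)O)nc2c1ncn2[C@@H]1O[C@H](CO)[C@@H](O)[C@H]1O` is measured in an assay on CHO cells for displacement of a labelled ligand from adenosine receptor A3 (Homo sapiens) (a lower number here means a stronger inhibitor, a higher number a weaker inhibitor), and gives 5.4 nM, the higher of the two numbers known. Compound 2 `CONc1nc(C#CC2CCCCC2O)nc2c1ncn2[C@@H]1O[C@H](CO)[C@@H](O)[C@H]1O` gives 1.7 nM in this assay, and the step of a 3.2-fold lower number from compound 1 to compound 2 (0.50 log units; beyond the scatter) is modest but beyond the scatter. Compound 3 `C#Cc1nc(NOC)c2ncn([C@@H]3O[C@H](CO)[C@@H](O)[C@H]3O)c2n1` differs from compound 1 by hydrogen in place of 2-hydroxypropyl on a triple-bonded carbon. Going by the values given here, only the step from compound 1 to compound 2 bears on this change, and it points the other way: enlarging the substituent helped, so removing it is expected to raise the number. Compound 3 is therefore estimated at 15 nM (range 4 nM to 60 nM), a step of a 2.8-fold higher number from compound 1 to compound 3 (0.44 log units; beyond the scatter).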

Compound 3, inhibition constant: 23 nM
Beside the measured number, compound 3's estimate is 1.5-fold (0.19 log units) below it; low and high end bracket the measured number.
By their numbers in this assay, from the lowest: compound 2; then compound 1; then compound 3.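

In this assay the substituent on the triple-bonded carbon proves to count: hydrogen in place of 2-hydroxypropyl gives a 4.3-fold higher number from compound 1 to compound 3 (0.63 log units; beyond the scatter) and hydrogen in place of 2-hydroxycyclohexyl gives a 14-fold higher number from compound 2 to compound 3 (1.13 log units; beyond the scatter), the larger of the two steps. The earlier pair compared only one substituent with another, whereas compound 3 shows that either one gives a lower number than none at all. Nothing measured here gives a reason for these steps.

Going by these compounds, whether the hydroxyl itself matters stays open: a longer chain without it, or an amine in its place, would separate the oxygen's share from that of the carbons.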